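Aryl swap on the shared core: compound 3 to compound 4

This account rests on a few compounds, and the source may have more. Where it says the series, first, only, none or still open, it means among the compounds named here.

Three members of the series have been run in an ADME assay on Vero cells (Chlorocebus sabaeus) for cytotoxicity, read by neutral red uptake, tested at 25 ug/mL (a lower number here means a stronger effect, a higher number a weaker effect of the compound at the concentration tested), so far. Compound 1 `O=C1CSC(c2cccc(O)c2)N1CCN1CCCCC1` gives 100% in this assay. Compound 2 `O=C1CSC(c2ccc([N+](=O)[O-])cc2)N1CCN1CCCCC1` gives 100% in this assay. Compound 3 `O=C1CSC(c2cccc(F)c2)N1CCN1CCCCC1` gives 100% in this assay. Within the data shown here, the one single-point change among them, fluoro in place of hydroxy on an aromatic carbon, gives no change at the digits printed from compound 1 to compound 3 (within the scatter). Compound 3 therefore stands level with compound 1 and compound 2 at the digits shown; no step listed so far has moved the read-out beyond the scatter.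

Compound 4 `O=C1CSC(c2ccc(Cl)cc2)N1CCN1CCCCC1` is next for this assay. It differs from compound 3 by 4-chlorophenyl in place of 3-fluorophenyl on a saturated ring carbon. The step that bears on it is the aryl-substituent change from compound 1 to compound 3, which gave no change within the scatter; the values of compound 2 and compound 3 are likewise the same at the digits shown, though no step between them is computed. On that basis the move from compound 3 to compound 4 is expected to give no change at the digits printed from compound 3 to compound 4 (within the scatter), that is, no step beyond the scatter. Compound 4 is accordingly estimated at 100% in this assay, with a range from 88% to 100%.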

Compound 4, a percentage reported as activity, at one concentration (the size of the read-out at that concentration, not a potency): 84%
The estimate for compound 4 lay 16 percentage points above the measured number; measured number below the stated range.
By their numbers in this assay, from the lowest: compound 4; then compounds 1, 2 and 3 (each within the scatter of the next).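

In this assay the aryl group on the saturated ring carbon of the shared core is the first place where the read-out moves: 4-chlorophenyl in place of 3-fluorophenyl gives a number 16 percentage points lower from compound 3 to compound 4 (beyond the scatter) and 4-chlorophenyl in place of 3-hydroxyphenyl gives a number 16 percentage points lower from compound 1 to compound 4 (beyond the scatter) while the other aryl groups shown stay level with each other. Chloro in place of nitro on an aromatic carbon gives a number 16 percentage points lower from compound 2 to compound 4 (beyond the scatter) and this step swaps only the substituent, so a change of substituent alone is enough to move the number, whereas the step from 3-fluorophenyl to 4-chlorophenyl changes the halogen and its place together and cannot separate the two. Nothing measured here accounts for the lower number of compound 4.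

Open, from the compounds shown here alone, is whether 3-chlorophenyl would stand with compound 3 or with compound 4, which would tell the halogen from its place on the ring. Also open, going by these compounds, is whether bromo or methoxy in place of the chloro would follow compound 4 or stay level with compounds 1, 2 and 3.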